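The source may report more compounds than this note shows. Statements on the series, on what has been measured and on what is new or still open speak of the compounds shown alone.

Measured so far in a physicochemical assay for solubility, in phosphate buffer, measured as kinetic solubility, with a stated time of 24 h, at pH 7.4; a lower number here means a less soluble compound, a higher number a more soluble compound:
- compound 1 `CC(C)CN(Cc1ccc(N2CCC(O)CC2)cc1)S(=O)(=O)Cc1ccccc1`: 7000 nM
- compound 2 `COC1CCN(c2ccc(CN(CC(C)C)S(=O)(=O)Cc3ccccc3)cc2)CC1`: <= 1000 nM (a limit)
- compound 3 `CC(=O)N1CCN(c2ccc(CN(C(C)(C)C)S(=O)(=O)Cc3ccccc3)cc2)CC1`: <= 1000 nM (a limit)

Compound 3 is known only as a limit, <= 1000 nM. Going by these compounds, this is the limit of <= 1000 nM in this assay, at which 2 of the 3 values shown sit, so its true value remains open.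

Compound 4 `CC(=O)N1CCN(c2ccc(CN(C)S(=O)(=O)Cc3ccccc3)cc2)CC1` differs from compound 3 by methyl in place of tert-butyl on a sulfonamide nitrogen. Among the compounds with values here, no measured step covers this nitrogen. Within the data shown here, the one measured step, with a methyl entering in compound 2, is an at least 7.0-fold lower number from compound 1 to compound 2 (0.84 log units; beyond the scatter). That change sits elsewhere, as methyl in place of hydrogen on an oxygen on a saturated carbon, so it serves only as a loose guide. Here carbon leaves instead of entering, so the opposite direction is expected in this assay, towards a higher number and beyond the scatter. The expected move is an at least 6.0-fold higher number from compound 3 to compound 4 (0.77 log units; beyond the scatter). A reading at the limit also remains possible. For compound 4 the estimate is 6000 nM, with an expected range of 1000 nM to 40000 nM.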

Compound 4, solubility: 7000 nM
Compound 4: middle estimate off by 1.2-fold (0.07 log units), on the low side; low and high end bracket the measured number.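

In this assay, within the data shown here, the sulfonamide nitrogen proves to be a position that responds: methyl in place of tert-butyl gives an at least 7.0-fold higher number from compound 3 to compound 4 (0.84 log units; beyond the scatter) and is the first measured step at this nitrogen. The earlier step lay on an oxygen on a saturated carbon, so the series now has a second place of change beyond the scatter, this one towards a higher number. Compound 3 is a limit, so the step has only a lower bound, and its true size stays unknown: the limit of <= 1000 nM in this assay, at which 2 of the 4 values shown sit.

In the core shared by compound 3 and compound 4, only tert-butyl and methyl are shown on this nitrogen, so the course between them stays open, and an ethyl group or a longer chain carrying an amine would add points. Going by these compounds, whether the same change gives a step of similar size in the core of compound 1 also stays open.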